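The source may report more compounds than this note shows. Statements on the series, on what has been measured and on what is new or still open speak of the compounds shown alone.

Working notes on the series. Within the data shown here, in an assay on HeLa cells with Bile acid receptor (Homo sapiens) as the target, read by a luciferase reporter, with a stated time of 24 h (on this read-out lower numbers stand for an effect already at smaller amounts and higher numbers for an effect only at larger amounts of compound), compound 2 `CC(C)(C)c1ccc(C(=O)NCc2ccc(C(=O)O)c(Cl)c2)cc1` gives 8.8 nM, the lower of the two numbers recorded so far; the only other measured member, compound 1 `CC(C)(C)c1ccc(C(=O)NCc2ccc(C(=O)O)cc2Cl)cc1`, gives 7500 nM in this assay, and the gap between these two values lies well beyond the usual scatter. Among the measured compounds shown here, no single-point step between measured compounds is recorded, so the effect of changing one group at a time on the shared core remains untested.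

Compound 3 `Cc1cc(CNC(=O)c2ccc(C(C)(C)C)cc2)ccc1C(=O)O` is the next member to be measured. The change from compound 2 is methyl in place of chloro on an aromatic carbon: the methyl takes the place of the chloro on an aromatic carbon of a six-membered aromatic ring of carbon only, ortho to a carboxy group. For the measured compounds named here, with no comparable step in hand, a modest step in this assay is expected, most likely toward a slightly higher number, though a value within the scatter of compound 2 would not surprise. For compound 3 the expected step is a 2.3-fold higher number from compound 2 to compound 3 (0.36 log units; beyond the scatter). Compound 3 is estimated to give 20 nM in this assay, with a range from 5 nM to 80 nM.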

Compound 3, half-maximal effective concentration: 160 nM
Compound 3: the middle estimate sits 8.0-fold (0.90 log units) below what was measured; the whole stated range lies below it.
By their numbers in this assay, from the lowest: compound 2; then compound 3; then compound 1.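

In this assay, among these compounds, the first single-point step is an 18-fold higher number from compound 2 to compound 3 (1.26 log units; beyond the scatter), so the group ortho to a carboxy group has a large bearing on the read-out. The exchange involves one heavy atom for one heavy atom, with no ring, no hydrogen-bond donor or acceptor and no net charge on either side, so these counts do not separate chloro from methyl. Nothing on hand bears on what lies behind this step.

On these data alone, whether bromo, fluoro, methoxy or plain hydrogen at this place would give a number nearer that of compound 2 or that of compound 3 remains open. Also open, as far as these compounds go, is whether the same exchange would give a step of similar size with an amine or a longer chain elsewhere on the shared core.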